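The source may hold more compounds than are shown below. What is called first, only, known or untested is meant among the compounds shown, and "the series" means these compounds.

Working notes on the series, tested in a functional assay on OVCAR-5 cells (Homo sapiens) for inhibition, read by sulforhodamine B assay, with a stated time of 48 h; a lower number here means a stronger inhibitor of growth, a higher number a weaker inhibitor of growth. Compound 1 `Nc1cc(N)c2nc(-c3ccccc3)c(NCc3ccc(Cl)c(Cl)c3)nc2c1` gives 40700 nM in this assay. Compound 3 `Nc1cc(N)c2nc(-c3ccccc3)c(Oc3ccc(F)cc3)nc2c1` gives 47900 nM in this assay, a number that lies within the usual scatter of the value of compound 1, so the two are not separated. Compound 2 `CCOC(=O)[C@H](CCC(=O)O)NC(=O)c1ccc(Sc2nc3cc(N)cc(N)c3nc2-c2ccccc2)cc1` gives only a limit of the assay, < 100000 nM, in this assay. Of the two numbers shown, compound 1 holds the lower one, with compound 3 close by; the third entry is a limit, (the limit of < 100000 nM in this assay, at which 1 of the 3 values shown sits). For the measured compounds named here, no step between measured compounds that differ in a single place is available. Compound 4 `COc1ccc(CNc2nc3cc(N)cc(N)c3nc2-c2ccccc2)cc1` is not yet measured. It differs from compound 1 as follows: 4-methoxyphenyl in place of 3,4-dichlorophenyl on a saturated chain carbon bound to a nitrogen on an aromatic ring. Compound 1 and compound 3 differ in more than one place and still show no separation beyond the scatter, so an exchange of the 3,4-dichlorobenzyl group alone gives no grounds for a large step. The step of a 1.2-fold higher number from compound 1 to compound 4 (0.09 log units; within the scatter) is therefore expected to stay within or close to the scatter. Compound 4 is estimated at 50000 nM, with a range from 15000 nM to 150000 nM.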

Compound 4, concentration for total growth inhibition: 45700 nM
For compound 4 the middle estimate is 1.1-fold (0.04 log units) above the measured one; the range from low to high includes it.
By their numbers in this assay, from the lowest: compounds 1, 4 and 3 (each within the scatter of the next).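

For the compounds shown here, the step of a 1.1-fold higher number from compound 1 to compound 4 (0.05 log units; within the scatter) in this assay is the first comparison that isolates a single place, on a saturated chain carbon bound to a nitrogen on an aromatic ring. The 3,4-dichlorobenzyl to 4-methoxybenzyl exchange replaces two chlorine atoms and adds a methoxy oxygen, counted as one hydrogen-bond acceptor, without separating the two compounds. The earlier compounds differed in more than one place and could not show this, and nothing measured here accounts for the flat step.

Going by these compounds, with one exchange read at this place, it remains open whether an amine or a carboxylic acid on the benzyl ring, or a longer chain, would give a step beyond the scatter. Compound 2 stands as a limit and not a number: the limit of < 100000 nM in this assay, at which 1 of the 4 values shown sits.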